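Shifting a Chlorine on a Compound Reported Not Active

This account rests on a few compounds, and the source may have more. Where it says the series, first, only, none or still open, it means among the compounds named here.

Growth inhibition of human lung-derived cells is a simple first screen: cells are exposed to a compound and the share of growth lost is recorded. Among the compounds with values here, in a functional assay on NCI-H460 cells (Homo sapiens) for inhibition, read by MTT assay, with a stated time of 24 h, tested at 100 ug/mL (a higher number here means more inhibition of growth at the concentration tested, a lower number less inhibition of growth), compound 1 (`O=C(O)CCCCC(CCSC(=O)c1ccccc1)SC(=O)c1ccccc1`) gives 72.8% and is the only compound here with a number. Compound 2 (`O=C(CCCCC(CCSC(=O)c1ccccc1)SC(=O)c1ccccc1)Nc1ccccc1`) and compound 3 (`O=C(CCCCC(CCSC(=O)c1ccccc1)SC(=O)c1ccccc1)Nc1ccccc1Cl`) both carry an amide-type nitrogen that compound 1 lacks. Compound 2 reads "not active" (no number reported) in this assay and so gives no single number. Compound 3 stands in the same place with "not active" (no number reported) as its entry, so no exact starting value exists for the next step.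

Compound 4 (`O=C(CCCCC(CCSC(=O)c1ccccc1)SC(=O)c1ccccc1)Nc1cccc(Cl)c1`) has not yet been measured. The structural change is 3-chlorophenyl in place of 2-chlorophenyl on an amide-type nitrogen with 3-chlorophenyl in place of 2-chlorophenyl on an amide-type nitrogen. The two compounds have the same atoms, joined differently. The expectation is no step beyond the usual scatter, since compound 3 reads "not active" (no number reported) and this small change keeps the amide-type nitrogen. Within the data shown here, only two such compounds have been tested, so this expectation is tentative, and a plain "not active" report is quite likely. If a number is reported, compound 4 is expected to give 10% with an estimated range from 0% to 35% in this assay here.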

Compound 4, percent growth inhibition at one concentration: "not active" (no number reported)
For compound 4 the study gives words and no number, and the estimate cannot be compared.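

Compound 3 and compound 4 are both reported as "not active" in this assay, without a number, so no step can be read for the change from 2-chlorophenyl to 3-chlorophenyl. No measurement shown here bears on this result. The compounds shown leave open whether the chlorine's position matters at all for growth inhibition.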